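The source may report more compounds than this note shows. Statements on the series, on what has been measured and on what is new or still open speak of the compounds shown alone.

compound 1 (`Cc1ccc(CNC(=O)CCN(Cc2ccc(C(=O)NO)cc2)C(=O)c2ccc(N(C)C)cc2)cc1`) gives 430 nM
compound 2 (`CN(C)c1ccc(C(=O)N(CCC(=O)NCc2ccc(Cl)cc2)Cc2ccc(C(=O)NO)cc2)cc1`) gives 460 nM

In a functional assay on G55T2 cells (Homo sapiens) for antiproliferative activity, read by WST assay, with a stated time of 72 h (a higher number here means a weaker inhibitor, a lower number a stronger inhibitor), compound 2 stands at 460 nM and is level with compound 1 within the scatter. Compound 3 (`Cc1ccc(NC(=O)CCN(Cc2ccc(C(=O)NO)cc2)C(=O)c2ccc(N(C)C)cc2)cc1`) differs from compound 2 in one place (4-methylphenyl in place of 4-chlorobenzyl on an amide-type nitrogen), with 4-methylphenyl in place of 4-chlorobenzyl on an amide-type nitrogen. Going by the values given here, the one measured step (a 1.1-fold higher number from compound 1 to compound 2 (0.03 log units; within the scatter)) covers only chloro in place of methyl and stays within the scatter. Among the compounds with values here, the change from benzyl to phenyl has no measured counterpart. No step beyond the scatter is expected in this assay and the estimated step (a 1.1-fold higher number from compound 2 to compound 3 (0.04 log units; within the scatter)) has no firm direction. Compound 3 is expected at 500 nM (estimated range 200 nM to 1200 nM).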

Compound 3, half-maximal inhibitory concentration: 330 nM
Compound 3: middle estimate off by 1.5-fold (0.18 log units), on the high side; measured number inside the range.
By their numbers in this assay, from the lowest: compounds 3, 1 and 2 (each within the scatter of the next).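

In this assay, the change from benzyl to phenyl on the amide-type nitrogen, which the earlier pair did not cover, reads as a 1.3-fold lower number from compound 1 to compound 3 (0.11 log units; within the scatter) with the methyl group kept, and as a 1.4-fold lower number from compound 2 to compound 3 (0.14 log units; within the scatter) with chloro also gone. Both steps stay within the scatter, so among these compounds this position accepts 4-methylphenyl as well as either benzyl group. No available evidence bears on this result. Still open, going by these compounds, is whether a longer chain or a carboxylic acid in place of 4-methylphenyl on this nitrogen would give a step beyond the scatter.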